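A few compounds are considered here, and "the series" means these few. Any claim that something is new, unique, unknown or untested is made for them only; others in the source may bear on it.

Measured compounds in a functional assay on HEp-2 cells (Homo sapiens) for antiproliferative activity, read by MTT assay, with a stated time of 72 h; a lower number here means a stronger inhibitor, a higher number a weaker inhibitor: compound 1 `O=c1c(CSC(=S)N2CCCC2)coc2ccccc12` gives 3600 nM; compound 2 `O=c1c(CSC(=S)N2CCOCC2)coc2ccccc12` gives 4400 nM.

On these two numbers compound 2 stands highest, with compound 1 as its nearest neighbour, and the step of a 1.2-fold higher number from compound 1 to compound 2 (0.09 log units; within the scatter) lies within the scatter, so the two compounds are indistinguishable here. Compound 3 `CC(C)N(C(=S)SCc1coc2ccccc2c1=O)C(C)C` has not yet been measured in this assay. The change from compound 2 to compound 3 is diisopropylamino in place of morpholin-4-yl on a thiocarbonyl carbon. Among the compounds with values here, the only measured step that bears on this position is the one from compound 1 to compound 2, where one cyclic amine replaced another on the thiocarbonyl carbon without a shift beyond the scatter. No acyclic amine has been tried at this place, so the step to compound 3 is expected to be a 1.1-fold lower number from compound 2 to compound 3 (0.04 log units; within the scatter), that is, no change beyond the scatter. Compound 3 is therefore estimated at 4000 nM, within 1800 nM to 9000 nM.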

Compound 3, half-maximal inhibitory concentration: 3000 nM
Beside the measured number, compound 3's estimate is 1.3-fold (0.12 log units) above it; measured number inside the range.
By their numbers in this assay, from the lowest: compounds 3, 1 and 2 (each within the scatter of the next).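

In this assay, replacing the ring with an open-chain amine gives a 1.5-fold lower number from compound 2 to compound 3 (0.17 log units; within the scatter), and the change from the other cyclic amine gives a 1.2-fold lower number from compound 1 to compound 3 (0.08 log units; within the scatter). Both steps lie within the scatter, so on the thiocarbonyl carbon this position tolerates diisopropylamino, which has no ring, as well as pyrrolidin-1-yl and morpholin-4-yl, whereas the earlier compounds had shown only an exchange of one ring for another. No measurement offered here explains why the three numbers sit so close together.

As far as these compounds go, it remains open whether a smaller group such as dimethylamino, or an amine with a free hydrogen such as piperazin-1-yl, would move the number beyond the scatter at this place. The compounds shown also leave open whether any substituent on the shared core would do so.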